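A phenyl in place of 2,4-difluorophenyl

The source may hold more compounds than are shown below. What is called first, only, known or untested is meant among the compounds shown, and "the series" means these compounds.

Compound 1: > 100000 nM
Compound 2: 18500 nM

Of the compounds shown here, two have been tested in a functional assay on HCT-116 cells (Homo sapiens) for inhibition, read by colorimetric assay, with a stated time of 3 days; a higher number here means a weaker inhibitor, a lower number a stronger inhibitor. Compound 1 `O=C(CCCCCCNC(=O)c1cc(=O)c(O)co1)Nc1ccccc1` gives > 100000 nM, which is a limit of the assay and not a number. Within the data shown here, compound 2 `O=C(CCCCCCNC(=O)C(O)(O)C(F)(F)F)Nc1ccc(F)cc1F` gives 18500 nM, the only actual number so far, so there is no series of values against which to rank it.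

Compound 3 `O=C(CCCCCCNC(=O)C(O)(O)C(F)(F)F)Nc1ccccc1` keeps the structure of compound 2 except for one change: phenyl in place of 2,4-difluorophenyl on an amide-type nitrogen. Among the measured compounds shown here, no measured pair of compounds shows what this change does, so the expectation rests on compound 2 at 18500 nM. No shift beyond the scatter in either direction is expected in this assay. The expected change is a 1.0-fold lower number from compound 2 to compound 3 (0.01 log units; within the scatter). The estimated value for compound 3 is 18000 nM, with an expected range of 6000 nM to 55000 nM.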

Compound 3, half-maximal inhibitory concentration: 9140 nM
Beside the measured number, compound 3's estimate is 2.0-fold (0.29 log units) above it; low and high end bracket the measured number.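

In this assay, phenyl in place of 2,4-difluorophenyl on an amide-type nitrogen gives a 2.0-fold lower number from compound 2 to compound 3 (0.31 log units; beyond the scatter), so the two fluorines are not needed for this level of inhibition. With phenyl now on both sides of a comparison, changing only the group on the carbonyl carbon gives an at least 10-fold lower number from compound 1 to compound 3 (1.03 log units; beyond the scatter). Compound 1 gives a limit of the assay rather than a number, so the true size of that step is unknown: the limit of > 100000 nM in this assay, at which 1 of the 3 values shown sits.

The compounds shown leave open whether a single fluorine on the phenyl ring would behave like phenyl or like 2,4-difluorophenyl, and what a chlorine or a methoxy group there would do. They also leave open how a shorter or longer chain would change the inhibition.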